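A few compounds are considered here, and "the series" means these few. Any claim that something is new, unique, unknown or untested is made for them only; others in the source may bear on it.

Compound 2, `c1ccc2c(c1)CN[C@@H](CN(CCCCNCc1ccncc1)[C@H]1CCCc3cccnc31)C2`, gives 22.7 nM in a functional assay on cells for antagonist activity at C-X-C chemokine receptor type 4 (Homo sapiens), read by fluorescence and calcium flux, with stated times of 25 min and 90 s (a higher number here means a weaker inhibitor, a lower number a stronger inhibitor), the lowest of the two numbers measured; its nearest neighbour is compound 1, `c1ccc2c(c1)CN[C@@H](CN(CCCCN(Cc1ccncc1)Cc1ccncc1)[C@H]1CCCc3cccnc31)C2`, which gives 832 nM. Compound 3, `c1ccc2c(c1)CN[C@@H](CN(CCCCNCC1CCOCC1)[C@H]1CCCc3cccnc31)C2`, differs from compound 2 by oxan-4-yl in place of pyridin-4-yl on a saturated chain carbon bound to an amine nitrogen. For the measured compounds named here, the one measured step, a 37-fold lower number from compound 1 to compound 2 (1.56 log units; beyond the scatter), removes a whole (pyridin-4-yl)methyl group rather than swapping one ring for another, so it bears only loosely on this change. A modest weakening beyond the scatter is therefore expected, a 2.4-fold higher number from compound 2 to compound 3 (0.38 log units; beyond the scatter). Compound 3 is estimated at 55 nM, within a range from 15 nM to 200 nM.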

Compound 3, half-maximal inhibitory concentration: 52.9 nM
Estimate against measurement, compound 3: 1.0-fold (0.02 log units) above; the measured number falls inside the stated range.
By their numbers in this assay, from the lowest: compound 2; then compound 3; then compound 1.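

In this assay, putting oxan-4-yl in place of pyridin-4-yl on the saturated chain carbon bound to the amine nitrogen gives a 2.3-fold higher number from compound 2 to compound 3 (0.37 log units; beyond the scatter) as a modest loss. A non-aromatic ring with the same heavy-atom count is therefore tolerated at this position, and an aromatic ring is not required for activity. No measurement here accounts for the size of this loss. This change alters both ring aromaticity and the ring hetero atom, and these compounds do not separate the two. A phenyl or piperidin-4-yl ring on the same carbon would help tell them apart.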